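Bromo for Fluoro on a Shared Core: Growth Inhibition

The compounds below may be only part of what the source reports. "The series", "measured", "known", "first", "only" and "open" are said of these compounds alone.

Of the compounds shown here, three on one shared core have been measured so far: compound 1 `O=C1NC(=S)/C(=C/c2ccccc2Br)S1`, compound 2 `O=C1NC(=S)/C(=C/c2cccc(F)c2)S1` and compound 3 `O=C1NC(=S)/C(=C/c2ccccc2F)S1`. In a functional assay on NCI-H292 cells (Homo sapiens) for cytotoxicity, read by MTT assay, with a stated time of 72 h, tested at 5 ug/mL (on this read-out higher numbers stand for more inhibition of growth at the one concentration tested and lower numbers for less inhibition of growth), compound 1 gives 22.9%, compound 2 gives 13.1% and compound 3 gives 25.2%. Compound 2 and compound 3 have the same atoms joined differently; the difference between their two cores is not broken down here. Compound 3 inhibits growth more than compound 2, a gap beyond the scatter, whereas compound 1 and compound 2 lie within the scatter of each other. Going by the values given here, the one single-point change that is measured, (bromo in place of fluoro on an aromatic carbon), gives a number 2.3 percentage points lower from compound 3 to compound 1 (within the scatter).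

Compound 4 `O=C1NC(=S)/C(=C/c2cccc(Br)c2)S1` has not been measured. It arises from compound 2 by bromo in place of fluoro on an aromatic carbon. This is the same kind of change as that from compound 3 to compound 1, but the place differs: there the group sits ortho to a group of 8 heavy atoms, here meta to a group of 8 heavy atoms. The step from compound 2 to compound 4 is expected to be a number 0.9 percentage points higher from compound 2 to compound 4 (within the scatter), because a number 2.3 percentage points lower from compound 3 to compound 1 (within the scatter) stayed within the scatter. Compound 4 is therefore estimated at 14%, expected between 4% and 26%.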

Compound 4, percent growth inhibition at one concentration: 22%
For compound 4 the middle estimate is 8 percentage points below the measured one, within the range that was stated.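

In this assay, bromo in place of fluoro on an aromatic carbon gives a number 8.9 percentage points higher from compound 2 to compound 4 (within the scatter), and the two readings of this change, taken on two cores, do not differ: the same change on two cores in this assay, a number 2.3 percentage points lower (within the scatter) from compound 3 to compound 1 and a number 8.9 percentage points higher (within the scatter) from compound 2 to compound 4, 11.2 percentage points apart, within the scatter of two such steps. On these two pairs, then, the change carries from one core to the other in the sense that neither step leaves the scatter, even though the group sits at a different place in each pair. This does not show that the swap is without effect on growth inhibition, and two pairs tested at a single concentration give no rule for the series or for other cores.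

The compounds shown carry only fluoro or bromo on the aromatic ring, so they leave open how an amine, a carboxylic acid or a methoxy group at the same places would read. They also leave open whether chloro would fall in with fluoro and bromo on these cores.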